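Working notes: from compound 2 toward compound 3

The compounds below may be only part of what the source reports. "The series", "measured", "known", "first", "only" and "open" are said of these compounds alone.

Measured so far:
compound 1 `COc1cc(C)cc(-c2nn(CC#N)cc2-c2ccc(-c3cccc(C(C)=O)c3)nc2)c1`, in a functional assay on LOX IMVI cells (Homo sapiens) for cytotoxicity, read by sulforhodamine B assay, with a stated time of 48 h, tested at 10 uM (on this read-out lower numbers stand for a stronger effect and higher numbers for a weaker effect at the one concentration tested), compound 1 gives 6%
compound 2 `Cc1cc(O)cc(-c2nn(CC#N)cc2-c2ccnc(-c3ccc(Oc4ccccc4)cc3)c2)c1`, in this assay compound 2 gives -86%

Compound 2 stands lowest of the two numbers; its nearest neighbour is compound 1, whose number is higher by a margin well beyond the usual scatter of this kind of measurement. The two differ in several places at once, so nothing is known about what any single change contributes.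

The next compound, compound 3 `Cc1cc(O)cc(-c2nn(CC#N)cc2-c2ccnc(-c3ccc(N(C)C)cc3)c2)c1`, keeps the shared core of compound 2 and differs from it in one place only: dimethylamino in place of phenoxy on an aromatic carbon. Going by the values given here, no step between measured compounds covers this change, so its size cannot be read from the numbers at hand.

Compound 3 is expected to stay in the active region, though with a step upward in this assay that would exceed the scatter, estimated as a number 41 percentage points higher from compound 2 to compound 3 (beyond the scatter). For compound 3 the estimate in this assay is -45%, with a range from -90% to 10%.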

Compound 3, a percentage reported as activity, at one concentration (the size of the read-out at that concentration, not a potency): -87%
For compound 3 the middle estimate is 42 percentage points above the measured one; the measured number falls inside the stated range.
By their numbers in this assay, from the lowest: compounds 3 and 2 (each within the scatter of the next); then compound 1.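

In this assay, going by these compounds alone, the step of a number 1 percentage points lower from compound 2 to compound 3 (within the scatter) is the first reading of a single change, and it lies within the scatter: on an aromatic carbon para to a large group, dimethylamino and phenoxy cannot be told apart. For this pair, the six-membered aromatic ring of phenoxy is therefore not needed to keep the read-out, and a group of 3 heavy atoms serves in place of one of 7, although a read-out at one concentration says nothing about potency. No measurement at hand explains why the two groups match.

Going by these compounds, whether this tolerance extends beyond these two groups remains open: a carboxylic acid, a primary amine or a longer chain such as diethylamino at the same position would test it. Within the data shown here, compound 1 differs from compound 2 and compound 3 in several places, so no step to it can be read, and what the hydroxy group and the other parts of the shared core contribute also remains unresolved.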